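The source may report more compounds than this note shows. Statements on the series, on what has been measured and on what is new or still open speak of the compounds shown alone.

In a functional assay on NCI-H1993 cells (Homo sapiens) for inhibition, read by CCK-8 assay, with a stated time of 72 h (a lower number here means a stronger inhibitor, a higher number a weaker inhibitor), compound 1 (`Cn1nccc1-c1cnc2ncn(Cc3ccc4ncccc4c3)c2n1`) gives 7910 nM as its reading and compound 3 (`OCCn1cc(-c2cnc3ncn(Cc4ccc5ncccc5c4)c3n2)cn1`) gives 2330 nM as its reading. Compound 2 (`CNC(=O)c1ccc(-c2cnc3ncn(C(C)c4cc5cccnc5cc4C)c3n2)cc1F`) adds no number to compare: its entry is "not determined" (no result reported) and it plays no part here. Among the compounds with values here, compound 3 therefore holds the lower of only two numbers, and its standing rests on compound 1 alone.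

The next step leads to compound 4 (`c1cnc2ccc(Cn3cnc4ncc(-c5ccncc5)nc43)cc2c1`), where pyridin-4-yl stands in place of 1-(2-hydroxyethyl)-1H-pyrazol-4-yl on an aromatic carbon of the shared core (pyridin-4-yl in place of 1-(2-hydroxyethyl)-1H-pyrazol-4-yl on an aromatic carbon).

Within the data shown here, the one measured step at this place is a 3.4-fold lower number from compound 1 to compound 3 (0.53 log units; beyond the scatter) with 1-(2-hydroxyethyl)-1H-pyrazol-4-yl in place of 1-methyl-1H-pyrazol-5-yl, and it is the only guide to size. No six-membered aromatic ring has yet been measured here, so that step gives no direction for this change. A step no larger than that one is expected in this assay and most likely none beyond the scatter, with a slight lean towards a higher number.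

The estimated step is a 1.3-fold higher number from compound 3 to compound 4 (0.11 log units; within the scatter) in this reading of the data. For compound 4 the estimated value is 3000 nM with an expected range from 800 nM to 10000 nM around it.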

Compound 4, half-maximal inhibitory concentration: 1160 nM
Compound 4: middle estimate off by 2.6-fold (0.41 log units), on the high side; the measured number falls inside the stated range.
By their numbers in this assay, from the lowest: compounds 4 and 3 (each within the scatter of the next); then compound 1.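

In this assay, the first six-membered aromatic ring at this position, on an aromatic carbon next to the ring nitrogen, reads level with the hydroxyethyl pyrazole (a 2.0-fold lower number from compound 3 to compound 4 (0.30 log units; within the scatter)). This holds even though pyridin-4-yl has 0 hydrogen-bond donors and 6 heavy atoms, against 1 donor and 8 heavy atoms for 1-(2-hydroxyethyl)-1H-pyrazol-4-yl, so across these compounds neither the hydroxyethyl chain nor a five-membered ring appears necessary for this level of reading. The comparison with 1-methyl-1H-pyrazol-5-yl is clearer (a 6.8-fold lower number from compound 1 to compound 4 (0.83 log units; beyond the scatter)), which leaves that group with the highest number of the three, and no measurement at hand gives a reason for any of these differences.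

The compounds shown do not separate the effect of the point of attachment on the pyrazole from that of the chain on it, as 1-(2-hydroxyethyl)-1H-pyrazol-4-yl and 1-methyl-1H-pyrazol-5-yl differ in both. As far as these compounds go, how a plain phenyl ring, or a pyridin-4-yl carrying an amine or a carboxylic acid, would read at this position remains open.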